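Thiosemicarbazide series: hydrazone in place of the free amino group

This account rests on a few compounds, and the source may have more. Where it says the series, first, only, none or still open, it means among the compounds named here.

Measured compounds:
compound 1 `CC1=CC[C@@H]([C@@](C)(O)CCCC(C)(C)NC=S)CC1` gives 47900 nM
compound 2 `CC1=CC[C@@H]([C@@](C)(O)CCCC(C)(C)NC(=S)NN)CC1` gives > 100000 nM

In a functional assay on HT-29 cells (Homo sapiens) for cytotoxicity, read by sulforhodamine B assay (a higher number here means a weaker inhibitor of growth, a lower number a stronger inhibitor of growth), compound 1 gives 47900 nM. For compound 2 the assay reports only a limit, > 100000 nM, so no number is known for it. The step of an at least 2.0-fold higher number from compound 1 to compound 2 (0.31 log units; beyond the scatter) therefore has only a lower bound. Compound 2 stands at the limit of > 100000 nM in this assay, at which 1 of the 2 values shown sits, the weaker end of what the two values show.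

Compound 3 `CC1=CC[C@@H]([C@@](C)(O)CCCC(C)(C)NC(=S)N/N=C\c2ccccc2)CC1` differs from compound 2 by a group of 8 heavy atoms (7 carbon, 1 nitrogen; one six-membered aromatic ring of carbon only) in place of one nitrogen atom, on an amide-type nitrogen. Going by the values given here, the only measured step at this part of the molecule, an at least 2.0-fold higher number from compound 1 to compound 2 (0.31 log units; beyond the scatter), went from a number to a limit when the amino group entered; nothing measured tells how the larger benzylidene group at the same nitrogen behaves. With compound 2 known only as a limit, the direction of the change to compound 3 cannot be read from the data, and a result at the limit again is as plausible as a return toward the number of compound 1. Compound 3 is therefore estimated at 60000 nM, with a wide range from 10000 nM to 300000 nM, which means an expected step of an at least 1.6-fold lower number from compound 2 to compound 3 (0.22 log units; that floor lies within the scatter).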

Compound 3, concentration for total growth inhibition: 36500 nM
Compound 3: middle estimate off by 1.6-fold (0.22 log units), on the high side, within the range that was stated.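

In this assay, replacing the amino group on the amide-type nitrogen with the benzylidene hydrazone group gives an at least 2.7-fold lower number from compound 2 to compound 3 (0.43 log units; beyond the scatter), so this nitrogen accepts a group of 8 heavy atoms with a six-membered aromatic ring and the number returns from a limit to a measured value. Set against the simple thiocarbonyl compound, the same series shows a 1.3-fold lower number from compound 1 to compound 3 (0.12 log units; within the scatter), so the values of compound 1 and compound 3 cannot be told apart, and the full hydrazone group offers no measurable advantage over the much smaller starting structure. From the compounds shown here alone, the value of compound 2 is a limit, so the step away from it has only a floor and its true size stays unknown: the limit of > 100000 nM in this assay, at which 1 of the 3 values shown sits.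

Going by these compounds, it remains open whether the aromatic ring itself matters or whether the double bond of the hydrazone is enough, a question that an isopropylidene hydrazone, with no ring at all, would address. Also open, on these data alone, is whether a benzylidene ring carrying a methoxy group or a chlorine atom, or a pyridine ring in its place, would move the number beyond the scatter around compound 1 and compound 3.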